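Cytotoxicity notes: compound 4 against the three measured compounds

The compounds below may be only part of what the source reports. "The series", "measured", "known", "first", "only" and "open" are said of these compounds alone.

Measured so far in an ADME assay on HepG2 2.2.15 cells (Homo sapiens) for cytotoxicity; a lower number here means that less compound is tolerated, a higher number that more compound is tolerated:
- compound 1, `COCCNc1ncc(C(Oc2ccc3cc(Br)ccc3c2)c2ccc(Cl)cc2)s1`: compound 1 gives "not toxic" (no number reported).
- compound 2, `O=C(Nc1ncc(C(Oc2ccc3cc(Br)ccc3c2)c2ccc(Cl)cc2)s1)c1ccc(Br)cc1`: compound 2 gives only a limit, > 50000 nM.
- compound 3, `N#Cc1cccc(C(=O)Nc2ncc(C(Oc3ccc4cc(Br)ccc4c3)c3ccc(Cl)cc3)s2)c1`: compound 3 gives only a limit, > 50000 nM.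

Compound 3 therefore stands at the assay limit, not at a number, and so does one further compound, while compound 1 has no number at all. For the measured compounds named here, the only step between compounds that differ in one place is a step that the two limits leave unreadable from compound 2 to compound 3, and its size cannot be read from the two limits. What is known of the series is that (the limit of > 50000 nM in this assay, at which 2 of the 3 values shown sit), so no compound shown has yet produced a readable cytotoxic concentration.

Compound 4, `O=S(=O)(Nc1ncc(C(Oc2ccc3cc(Br)ccc3c2)c2ccc(Cl)cc2)s1)c1cccc2nsnc12`, differs from compound 3 as follows: a group of 12 heavy atoms (6 carbon, 2 nitrogen, 2 oxygen, 2 sulfur; one five-membered aromatic ring with 3 hetero atoms, one six-membered aromatic ring of carbon only) in place of a group of 10 heavy atoms (8 carbon, 1 nitrogen, 1 oxygen; one six-membered aromatic ring of carbon only), on a nitrogen on an aromatic ring.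

Going by the values given here, no measured step bears on this change in a readable way. With every value shown sitting at or beyond the limit, no step beyond the scatter is expected from compound 3 to compound 4; the expected step is a step that the limit leaves unreadable from compound 3 to compound 4. Compound 4 is accordingly estimated at 60000 nM in this assay, within a range from 15000 nM to 200000 nM, most likely again as a limit only.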

Compound 4, half-maximal cytotoxic concentration: "not toxic" (no number reported)
Compound 4 has no reported number here, so the estimate cannot be set against anything.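

In this assay compound 4 gives "not toxic" (no number reported), so no new step can be read from compound 3 to compound 4. The compounds shown leave open whether any of them has a readable cytotoxic concentration and how a change of group on the nitrogen would alter it, the only numerical anchor being: the limit of > 50000 nM in this assay, at which 2 of the 4 values shown sit.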